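Triazole-linked series: cytotoxicity on liver cells, next analogue

A few compounds are considered here, and "the series" means these few. Any claim that something is new, unique, unknown or untested is made for them only; others in the source may bear on it.

Measured so far in an ADME assay on L02 cells (Homo sapiens) for antiproliferative activity, read by MTT assay, with a stated time of 48 h; on this read-out higher numbers stand for weaker inhibition and lower numbers for stronger inhibition:
Compound 1 `CC(=O)Nc1ccc(-n2nncc2CN2C(=O)C3(C(C#N)=C(N)Oc4c(N)cc5nc6ccccc6nc5c43)c3ccccc32)cc1` gives > 50000 nM in this assay, which is a limit of the assay and not a number.
Compound 2 `COc1ccccc1-n1nncc1CN1C(=O)C2(C(C#N)=C(N)Oc3c(N)cc4nc5ccccc5nc4c32)c2ccccc21` gives > 50000 nM in this assay, again a limit of the assay.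
Compound 3 `CCOc1ccc(-n2nncc2CN2C(=O)C3(C(C#N)=C(N)Oc4c(N)cc5nc6ccccc6nc5c43)c3ccccc32)cc1` gives > 50000 nM in this assay, likewise a limit of the assay.

Compound 3 therefore stands at the same limit as the other two members, the limit at which all three values sit (the limit of > 50000 nM in this assay, at which 3 of the 3 values shown sit). Within the data shown here, none of the measured steps can be read: a step that the two limits leave unreadable from compound 1 to compound 2, a step that the two limits leave unreadable from compound 1 to compound 3 and a step that the two limits leave unreadable from compound 2 to compound 3 are all left unreadable by the two limits, so no size and no direction are known for any change on the aromatic nitrogen or on the aromatic carbon.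

Compound 4 `CCc1cccc(CC)c1-n1nncc1CN1C(=O)C2(C(C#N)=C(N)Oc3c(N)cc4nc5ccccc5nc4c32)c2ccccc21` is not yet measured. It differs from compound 3 by 2,6-diethylphenyl in place of 4-ethoxyphenyl on an aromatic nitrogen. The measured steps that bear on a change of the aryl group on this aromatic nitrogen give no readable size, so nothing beyond the scatter is expected in this assay, and the most likely outcome is that compound 4 also reaches only the limit. The expected value for compound 4 is 50000 nM, with a range of 20000 nM to 100000 nM. The step expected from compound 3 to compound 4 is a number no higher from compound 3 to compound 4 (the limit leaves the size open).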

Compound 4, half-maximal inhibitory concentration: > 50000 nM
Compound 4: no number, only a limit (the forecaster's own chance of this, stated with the estimate: 85%); the middle value lies on the limit itself.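

Compound 4 also gives only a limit and not a number, and its steps from compound 1, compound 2 and compound 3 cannot be read; all four compounds sit together: the limit of > 50000 nM in this assay, at which 4 of the 4 values shown sit. The compounds shown leave open whether any aryl group on this aromatic nitrogen gives a measurable value in this assay, and in which direction such a change would go.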